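The compounds below may be only part of what the source reports. "The series", "measured", "known", "first", "only" and "open" are said of these compounds alone.

Measured in an assay on CHO cells for binding affinity to metabotropic glutamate receptor 2 (Rattus norvegicus); on this read-out lower numbers stand for stronger inhibition and higher numbers for weaker inhibition:
compound 1, `N[C@]1(C(=O)O)[C@H]2[C@@H](C[C@H]1OCc1cc(F)cc(F)c1)[C@]2(F)C(=O)O`, 12.4 nM
compound 2, `N[C@]1(C(=O)O)[C@H]2[C@@H](C[C@H]1OCc1cc(F)ccc1F)[C@]2(F)C(=O)O`, 14.4 nM
compound 3, `N[C@]1(C(=O)O)[C@H]2[C@@H](C[C@H]1OCc1ccc(Cl)cc1Cl)[C@]2(F)C(=O)O`, 3.89 nM

Compound 3 gives the lowest number of the three; the steps to it are a 3.2-fold lower number from compound 1 to compound 3 (0.50 log units; beyond the scatter) and a 3.7-fold lower number from compound 2 to compound 3 (0.57 log units; beyond the scatter), both beyond the scatter, whereas compound 1 and compound 2 sit within the scatter of each other, a 1.2-fold higher number from compound 1 to compound 2 (0.06 log units; within the scatter).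

Compound 4, `N[C@]1(C(=O)O)[C@H]2[C@@H](C[C@H]1OCc1c(Cl)cccc1Cl)[C@]2(F)C(=O)O`, differs from compound 3 by 2,6-dichlorophenyl in place of 2,4-dichlorophenyl on a saturated chain carbon bound to an oxygen on a saturated carbon. The measured steps bear on this only loosely: each swaps one dihalophenyl for another, and none compares two dichlorophenyl groups. Such swaps have so far moved the number modestly or not beyond the scatter. For compound 4 a modest loss or none beyond the scatter is expected, the estimated step being a 1.8-fold higher number from compound 3 to compound 4 (0.26 log units; within the scatter). Compound 4 is estimated at 7 nM, within 2.5 nM to 25 nM.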

Compound 4, inhibition constant: 4.3 nM
Estimate against measurement, compound 4: 1.6-fold (0.21 log units) above; measured number inside the range.
By their numbers in this assay, from the lowest: compounds 3 and 4 (each within the scatter of the next); then compounds 1 and 2 (each within the scatter of the next).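

Both dichlorophenyl patterns give the same level within the scatter: this first comparison of two dichlorophenyl groups at this place shows a 1.1-fold higher number from compound 3 to compound 4 (0.04 log units; within the scatter) and no separation between them. Against the difluorophenyl compounds, the 2,6-dichlorophenyl group holds the advantage already seen with 2,4-dichlorophenyl, with a 3.3-fold lower number from compound 2 to compound 4 (0.52 log units; beyond the scatter) and a 2.9-fold lower number from compound 1 to compound 4 (0.46 log units; beyond the scatter) as steps beyond the scatter. No evidence on the cause of these results is available. Open, from the compounds shown here alone, is whether a monochlorophenyl, an unsubstituted phenyl or a 3,5-dichlorophenyl group would stay at this level.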